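The source may report more compounds than this note shows. Statements on the series, on what has been measured and on what is new or still open speak of the compounds shown alone.

Compound 1 `COc1ccc([C@H]2CC(=O)N(Cc3cccc([N+](=O)[O-])c3)C2)cc1OC1CCCC1` is the reference point of the series. In a functional assay on HEK293 cells (Homo sapiens) for cytotoxicity (a higher number here means that more compound is tolerated, a lower number that less compound is tolerated), compound 1 gives only the limit > 10000 nM, not a number. Two neighbours differ from compound 1 solely in the group on the amide-type nitrogen in the ring. Compound 2 `COc1ccc([C@H]2CC(=O)N(c3cc(N)cc(F)c3)C2)cc1OC1CCCC1` carries 3-amino-5-fluorophenyl on that nitrogen, and in this assay compound 2 also stays at the limit > 10000 nM. Compound 3 `COc1ccc([C@H]2CC(=O)N(c3cccc(C#N)c3)C2)cc1OC1CCCC1` carries 3-cyanophenyl on that nitrogen, and in this assay compound 3 returns the limit > 10000 nM too. The measured steps are therefore a step that the two limits leave unreadable from compound 1 to compound 2, a step that the two limits leave unreadable from compound 1 to compound 3 and a step that the two limits leave unreadable from compound 2 to compound 3; no size can be read from any of them because of the limit of > 10000 nM in this assay, at which 3 of the 3 values shown sit.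

The next compound is compound 4 `COc1ccc([C@H]2CC(=O)N(c3ccccc3C(F)(F)F)C2)cc1OC1CCCC1`. It differs from compound 1 as follows: 2-(trifluoromethyl)phenyl in place of 3-nitrobenzyl on an amide-type nitrogen in a ring. The three measured steps bear on it only insofar as every change on the amide-type nitrogen in the ring has so far left the read-out at the limit. No step beyond the scatter is expected in this assay in either direction, and a limit rather than a number is the likely outcome for compound 4. The step expected for compound 4 is a step that the limit leaves unreadable from compound 1 to compound 4. For compound 4 the estimate in this assay is 15000 nM, with a range from 7000 nM to 40000 nM.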

Compound 4, half-maximal cytotoxic concentration: > 10000 nM
Compound 4: no number, only a limit; the forecaster's own chance of this, stated with the estimate: 80%; the middle value does not contradict the limit.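

In this assay compound 4 gives > 10000 nM, a limit and not a number, so no step linking compound 4 with compound 1, compound 2 or compound 3 can be read: the limit of > 10000 nM in this assay, at which 4 of the 4 values shown sit.

The compounds shown leave open whether these four differ at all in this assay.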